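From ethyl ester to free acid in growth inhibition

The source may report more compounds than this note shows. Statements on the series, on what has been measured and on what is new or still open speak of the compounds shown alone.

Within the data shown here, in a functional assay on MDA-MB-231 cells (Homo sapiens) for inhibition, read by sulforhodamine B assay, with a stated time of 72 h (a lower number here means a stronger inhibitor of growth, a higher number a weaker inhibitor of growth), compound 1 `CCOC(=O)/C=C/c1ccncc1-c1ccc2cc[nH]c2c1` gives 7980 nM, the only exact number so far. Compound 2 `O=C(O)/C=C/c1ccncc1-c1ccc2ccccc2c1`, which also carries a carboxy group, reaches only a limit of the assay, > 10000 nM. Compound 3 `O=C(O)/C=C/c1ccncc1-c1ccc2cc[nH]c2c1` has the core of compound 1 but with hydrogen in place of ethyl on an oxygen next to a carbonyl group, which changes ethoxycarbonyl to carboxy. Among the measured compounds shown here, no measured pair shows this change, so only a modest weakening is expected in this assay, resting on that limit for compound 2. The expected step of a 1.5-fold higher number from compound 1 to compound 3 (0.18 log units; within the scatter) is small. Compound 3 is estimated at 12000 nM, within a range of 5000 nM to 30000 nM.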

Compound 3, concentration for 50% growth inhibition: > 10000 nM
Compound 3: no number, only a limit (the forecaster's own chance of this, stated with the estimate: 60%); the middle value lies beyond the limit too.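

Among these compounds, this pair gives the first direct reading of ethoxycarbonyl changed to carboxy on the core of compound 1: in this assay, the step is an at least 1.2-fold higher number from compound 1 to compound 3 (0.09 log units; that floor lies within the scatter). That floor shows no change beyond the scatter, yet the free acid gains no measurable growth inhibition. From the compounds shown here alone, the true size of the step stays unknown because the reading ends at a limit: the limit of > 10000 nM in this assay, at which 2 of the 3 values shown sit.

The compounds shown leave open how far beyond that limit compound 3 lies. They also leave open whether a methyl ester or an amide here would match compound 1.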